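Bromo in place of nitro on a phenol-bearing side arm

A few compounds are considered here, and "the series" means these few. Any claim that something is new, unique, unknown or untested is made for them only; others in the source may bear on it.

Of the compounds shown here, two built on one shared core have been measured so far. Compound 1 `CCOC(=O)N1CCC(N(Cc2ccc([N+](=O)[O-])cc2)C(=O)N(C)C)CC1` and compound 2 `CCOC(=O)N1CCC(N(Cc2cc([N+](=O)[O-])ccc2O)C(=O)N(C)C)CC1` differ only in the groups carried on one aromatic ring. In a functional assay on KB cells (Homo sapiens) for antiproliferative activity, read by MTT assay, with a stated time of 48 h (on this read-out lower numbers stand for stronger inhibition and higher numbers for weaker inhibition), compound 1 gives 16400 nM, and in the same assay compound 2 gives 24200 nM. Compound 2 has the higher of the two numbers, but its gap to compound 1 lies within the usual scatter of repeated measurements, so the two cannot be separated with confidence.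

Compound 3 `CCOC(=O)N1CCC(N(Cc2cc(Br)ccc2O)C(=O)N(C)C)CC1` follows from compound 2 by one change: bromo in place of nitro on an aromatic carbon. Among the measured compounds shown here, no measured pair shows this exchange, so there is no measured step to lean on; only two weak values on related compounds are known.

Compound 3 is therefore expected to stay near its parent, with a step of a 1.1-fold lower number from compound 2 to compound 3 (0.04 log units; within the scatter) that remains within the scatter and points in no firm direction. In this assay the estimate for compound 3 is 22000 nM, with a range from 8000 nM to 60000 nM.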

Compound 3, half-maximal inhibitory concentration: 24600 nM
Estimate against measurement, compound 3: 1.1-fold (0.05 log units) below; the range from low to high includes it.
By their numbers in this assay, from the lowest: compounds 1, 2 and 3 (each within the scatter of the next).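

In this assay, the exchange of nitro for bromo on the aromatic carbon para to a hydroxy group gives a step of a 1.0-fold higher number from compound 2 to compound 3 (0.01 log units; within the scatter), which lies within the scatter, so the two groups cannot be told apart at this position. This holds even though the change removes three heavy atoms and two hydrogen-bond acceptors and brings in a single bromine atom with no acceptor. The wider exchange of 4-nitrophenyl for 5-bromo-2-hydroxyphenyl gives a 1.5-fold higher number from compound 1 to compound 3 (0.18 log units; within the scatter), also within the scatter, and no independent measurement is available to explain how close these values lie.

The compounds shown leave open whether any group on this aromatic carbon can move the number beyond the scatter, for example an amine or a carboxylic acid in place of bromo. They also leave open what the hydroxy group does on its own, which only a pair of compounds differing in that group alone could show.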